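Replacing 1H-indol-6-yl with 4-(trifluoromethyl)phenyl

The compounds below may be only part of what the source reports. "The series", "measured", "known", "first", "only" and "open" are said of these compounds alone.

Measured in a functional assay on HCT-116 cells (Homo sapiens) for inhibition, read by CCK-8 assay, with a stated time of 48 h; a higher number here means a weaker inhibitor, a lower number a stronger inhibitor:
- compound 1 `COc1cc(-c2ccnc3cc(-c4ccc(Cl)cc4)nn23)cc(OC)c1OC` gives 3340 nM
- compound 2 `COc1cc(-c2ccnc3cc(-c4ccc(C)c(C)c4)nn23)cc(OC)c1OC` gives 261 nM
- compound 3 `COc1cc(-c2ccnc3cc(-c4ccc5cc[nH]c5c4)nn23)cc(OC)c1OC` gives 187 nM

Compound 3 sits at the low, more potent end of this small set, but it is not clearly separated there: a 1.4-fold lower number from compound 2 to compound 3 (0.14 log units; within the scatter) is a step that does not set the two apart. Compound 1 lies far from both.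

The next compound, compound 4 `COc1cc(-c2ccnc3cc(-c4ccc(C(F)(F)F)cc4)nn23)cc(OC)c1OC`, has 4-(trifluoromethyl)phenyl in place of 1H-indol-6-yl on an aromatic carbon. For the measured compounds named here, no measured compound carries this group, so the estimate rests on a comparison by analogy. By name, the nearest measured group is the 4-chlorophenyl of compound 1. Leaving that group gave two large steps, a 13-fold lower number from compound 1 to compound 2 (1.11 log units; beyond the scatter) and an 18-fold lower number from compound 1 to compound 3 (1.25 log units; beyond the scatter). If the new group behaves like 4-chlorophenyl, much of that gain is lost, and a clear rise in this assay is expected, though this single analogy is thin support.

The expected size of the move is an 11-fold higher number from compound 3 to compound 4 (1.03 log units; beyond the scatter), which would lie beyond the scatter. For compound 4 the estimated value is 2000 nM, with an expected range from 600 nM to 6000 nM for the measurement.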

Compound 4, half-maximal inhibitory concentration: 1860 nM
For compound 4 the middle estimate is 1.1-fold (0.03 log units) above the measured one; the range from low to high includes it.
By their numbers in this assay, from the lowest: compounds 3 and 2 (each within the scatter of the next); then compounds 4 and 1 (each within the scatter of the next).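

In this assay, compound 4 lands on the weak side of the set, whether it is set against the 1H-indol-6-yl of compound 3 (a 9.9-fold higher number from compound 3 to compound 4 (1.00 log units; beyond the scatter)) or against the 3,4-dimethylphenyl of compound 2 (a 7.1-fold higher number from compound 2 to compound 4 (0.85 log units; beyond the scatter)). The new information is that the high number of compound 1 is not special to chloro: putting trifluoromethyl in its place gives a step within the scatter (a 1.8-fold lower number from compound 1 to compound 4 (0.25 log units; within the scatter)), so 4-chlorophenyl and 4-(trifluoromethyl)phenyl cannot be told apart here, and both stay well away from the two more potent compounds. No supporting measurement is available to explain why these groups separate in this way.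

Going by these compounds, with only four compounds, it remains open whether other groups on a phenyl ring at this position, such as a single methyl, a methoxy, an amine or a carboxylic acid, would join the weak pair or the potent pair. It is also unclear how a plain unsubstituted phenyl would compare, and that compound would give a simple reference for judging all four groups.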